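This account rests on a few compounds, and the source may have more. Where it says the series, first, only, none or still open, it means among the compounds named here.

The compounds share one core, carrying an acrylamide-type side chain whose amide nitrogen bears the group that varies. Compound 1 `COc1ccc2c(=O)c(/C=C/C(=O)Nc3cccc(Cl)c3)coc2c1` is the starting point. In a functional assay on L02 cells (Homo sapiens) for inhibition, read by MTT assay, with a stated time of 48 h (a higher number here means a weaker inhibitor, a lower number a stronger inhibitor), compound 1 gives only a limit, > 200000 nM, not a number. Compound 2 `COc1ccc2c(=O)c(/C=C/C(=O)NCc3ccc(C)cc3)coc2c1` likewise reaches only a limit in this assay, > 200000 nM. Compound 3 `COc1ccc2c(=O)c(/C=C/C(=O)NCc3ccccc3F)coc2c1` also stops at a limit in this assay, > 200000 nM. Because of the limit of > 200000 nM in this assay, at which 3 of the 3 values shown sit, the three steps among these compounds cannot be read: a step that the two limits leave unreadable from compound 1 to compound 2, a step that the two limits leave unreadable from compound 1 to compound 3 and a step that the two limits leave unreadable from compound 2 to compound 3 all sit between values that are limits on both sides, so their sizes stay hidden. Compound 1 therefore stands at the limit of this assay, alongside the other two measured compounds, and nothing ranks them.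

Compound 4 `COc1ccc2c(=O)c(/C=C/C(=O)Nc3ccccc3OC)coc2c1` differs from compound 1 in one place: 2-methoxyphenyl in place of 3-chlorophenyl on an amide-type nitrogen. Among the compounds with values here, no measured step bears directly on this change, since every step recorded is unreadable. The expectation for compound 4 rests on the fact that compounds 1, 2 and 3 all stop at the limit, so a step that the limit leaves unreadable from compound 1 to compound 4 is expected, meaning no readable movement. Compound 4 is thus estimated to give about 250000 nM in this assay, within the range 100000 nM to 600000 nM, most probably reported as a limit again.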

Compound 4, half-maximal inhibitory concentration: > 200000 nM
Compound 4 was reported as a limit (the forecaster's own chance of this, stated with the estimate: 85%); the middle value lies beyond the limit too.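

In this assay compound 4 gives > 200000 nM, which is a limit and not a number. Its steps with compound 1, compound 2 and compound 3 cannot be read, because limits stand on both sides of each: the limit of > 200000 nM in this assay, at which 4 of the 4 values shown sit. The compounds shown leave open how strongly any of them inhibits, and whether the group on the amide-type nitrogen changes that at all.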